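Swapping a Hydroxyethyl Arm for Cyclopropyl

This account rests on a few compounds, and the source may have more. Where it says the series, first, only, none or still open, it means among the compounds named here.

Of the compounds shown here, two have been measured in an assay on isolated protein for inhibition of Rho-associated protein kinase 2 (Homo sapiens); a higher number here means a weaker inhibitor, a lower number a stronger inhibitor. Compound 1 `COc1cccc(CN(CCCN(C)C)C(=O)c2cn(C)c3cc(-c4cn[nH]c4)ccc23)c1` gives 1 nM, and compound 2 `COc1cccc(CNC(=O)c2cc3ccc(-c4cn[nH]c4)nc3n2CCCO)c1` gives 24 nM. Within the data shown here, of these two numbers compound 2 holds the higher one; its only neighbour is compound 1, whose number lies far lower, well beyond the usual scatter. The two structures differ in several places at once, so their gap says nothing about any single change.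

Compound 3 `COc1cccc(CNC(=O)c2cc3ccc(-c4cn[nH]c4)nc3n2CC2CC2)c1` differs from compound 2 in one place: cyclopropyl in place of 2-hydroxyethyl on a saturated chain carbon bound to an aromatic nitrogen. Among the measured compounds shown here, no measured pair of compounds shows this exact change, so no step is known for it. The expectation for compound 3 therefore rests on compound 2 alone, and the most cautious reading is a small step that need not exceed the usual scatter. In this assay compound 3 is thus expected to give 30 nM, with a range from 8 nM to 120 nM. That estimate corresponds to an expected step of a 1.3-fold higher number from compound 2 to compound 3 (0.10 log units; within the scatter), which is meant to stay close to the number of compound 2.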

Compound 3, half-maximal inhibitory concentration: 150 nM
Compound 3: the middle estimate sits 5.0-fold (0.70 log units) below what was measured; the whole stated range lies below it.
By their numbers in this assay, from the lowest: compound 1; then compound 2; then compound 3.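

In this assay, the group on a saturated chain carbon bound to an aromatic nitrogen proves able to shift the number: cyclopropyl in place of 2-hydroxyethyl gives a 6.3-fold higher number from compound 2 to compound 3 (0.80 log units; beyond the scatter), a step beyond the scatter. Both groups hold 3 heavy atoms, so this pair shows that the number responds to what those atoms are and how they are arranged, not to their count alone. The data offer no independent measurement that would explain the step.

This single swap removes the hydroxyl, with its hydrogen-bond donor and acceptor, and adds a three-membered carbon ring in the same step, so the compounds shown cannot tell which of these two changes matters. A plain propyl chain would lack the hydroxyl without adding the ring, while a 3-aminopropyl arm or a carboxylic acid on a chain at this place would show whether other heteroatom-bearing groups behave like the 3-hydroxypropyl arm of compound 2.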